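Swapping a chloro for a hydroxy-alkynyl chain on a cyclopropane-fused core

A few compounds are considered here, and "the series" means these few. Any claim that something is new, unique, unknown or untested is made for them only; others in the source may bear on it.

Measured so far:
Compound 1, `C=C/C=C1\C=C(C)C2(CC2)C(C)(O)C1=O`, gives 18 nM in a functional assay on A-375 cells (Homo sapiens) for antiproliferative activity; on this read-out lower numbers stand for stronger inhibition and higher numbers for weaker inhibition.
Compound 2, `CC1=C/C(=C\Cl)C(=O)C(C)(O)C12CC2`, gives 1000 nM in this assay.

For the measured compounds named here, compound 2 holds the higher of the two numbers seen so far, and the only step on record, a 56-fold higher number from compound 1 to compound 2 (1.74 log units; beyond the scatter), separates it from compound 1, the sole neighbour. Compound 3, `CC1=C/C(=C\C#CCCO)C(=O)C(C)(O)C12CC2`, is not yet measured. It differs from compound 2 in one place: 4-hydroxybut-1-yn-1-yl in place of chloro on a double-bonded chain carbon bound to a double-bonded ring carbon.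

Going by the values given here, the one step that bears on this change is the one between compound 1 and compound 2, in which an unsaturated carbon chain gave way to chloro and the number rose sharply. Compound 3 reverses that direction, putting a longer unsaturated carbon chain back where compound 2 carries chloro. Among the compounds with values here, a drop in the number beyond the scatter is therefore expected, though a chain of this length carrying a hydroxyl has no measured counterpart here, so the size is uncertain. Compound 3 is expected to give 60 nM in this assay, within 12 nM to 300 nM, which would mean a 17-fold lower number from compound 2 to compound 3 (1.22 log units; beyond the scatter).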

Compound 3, half-maximal inhibitory concentration: 2000 nM
The estimate for compound 3 lay 33-fold (1.52 log units) below the measured number; measured number above the stated range.
By their numbers in this assay, from the lowest: compound 1; then compounds 2 and 3 (each within the scatter of the next).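

The earlier step could suggest that any unsaturated carbon chain at this position would bring back the low number of compound 1, but this result does not support that reading. In this assay, 4-hydroxybut-1-yn-1-yl in place of chloro on the double-bonded chain carbon leaves the two compounds within the usual scatter of each other (a 2.0-fold higher number from compound 2 to compound 3 (0.30 log units; within the scatter)), so chloro and this longer chain cannot be told apart here, while the same chain in place of vinyl costs far more (a 110-fold higher number from compound 1 to compound 3 (2.05 log units; beyond the scatter)). Among these three compounds, then, only vinyl goes with a low number, although no supporting measurement explains why it stands apart.

The hydroxy-alkynyl chain differs from vinyl in several ways at once, so compound 3 cannot show whether the triple bond, the chain length or the hydroxyl goes with the weaker result. An ethynyl group, a plain but-1-yn-1-yl chain without the hydroxyl, or a propenyl group at this position would separate those features, and the compounds shown do not include any of them.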